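The source may hold more compounds than are shown below. What is called first, only, known or untested is meant among the compounds shown, and "the series" means these compounds.

Notes on the series in an assay on isolated protein for displacement of a labelled ligand from metabotropic glutamate receptor 5 (Homo sapiens), with a stated time of 60 min, tested at 1 uM; a lower number here means less inhibition, a higher number more inhibition at the concentration tested (going by the name of the read-out).

Three compounds share one core and differ at a single aromatic carbon. Compound 1 `CC1CCN(c2c(S(=O)(=O)c3ccc(Cl)cc3)cnc3ccc(F)cc23)CC1` gives 80%. Compound 2 `Cc1ccc2ncc(S(=O)(=O)c3ccc(Cl)cc3)c(N3CCC(C)CC3)c2c1` gives 79%. Compound 3 `CC1CCN(c2c(S(=O)(=O)c3ccc(Cl)cc3)cnc3ccc(Cl)cc23)CC1` gives 92%. The step of a number 1 percentage points lower from compound 1 to compound 2 (within the scatter) is within the scatter; the steps of a number 12 percentage points higher from compound 1 to compound 3 (beyond the scatter) and a number 13 percentage points higher from compound 2 to compound 3 (beyond the scatter) are beyond it but modest. Compound 2 therefore stands lowest of the three numbers, though its gap to compound 1 is within the scatter, and only compound 3 stands beyond it.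

Compound 4 `Cc1ccc2ncc(S(=O)(=O)c3cccc(Cl)c3)c(N3CCC(C)CC3)c2c1` is not yet measured. Its difference from compound 2 is 3-chlorophenyl in place of 4-chlorophenyl on a sulfonyl sulfur. Within the data shown here, this change sits on the sulfonyl sulfur, not on the aromatic carbon where the three measured steps occur, so no measured step bears on it directly. The measured values show only that varying a single aromatic substituent on this core moves the read-out by a modest amount at most. Among the measured compounds shown here, for compound 4 a lower number in this assay is expected, on the ground that no precedent supports the new arrangement, so the number for the rearranged group may be lower or level; the expected step is a number 11 percentage points lower from compound 2 to compound 4 (beyond the scatter). The estimate for compound 4 is 68%, with a range from 40% to 88%.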

Compound 4, a percentage reported as inhibition, at one concentration (the size of the read-out at that concentration, not a potency): 91%
For compound 4 the middle estimate is 23 percentage points below the measured one; the whole stated range lies below it.
By their numbers in this assay, from the lowest: compounds 2 and 1 (each within the scatter of the next); then compounds 4 and 3 (each within the scatter of the next).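

In this assay, 3-chlorophenyl in place of 4-chlorophenyl on the sulfonyl sulfur gives a number 12 percentage points higher from compound 2 to compound 4 (beyond the scatter) and is the only step shown at this place; the two groups have the same atoms and the same counts, so the arrangement of the group alone is enough to move the number. Compounds 1, 2 and 3 all carry 4-chlorophenyl and vary only an aromatic carbon of the shared core, so they left this place untested; the new step is modest and close in size to a number 13 percentage points higher from compound 2 to compound 3 (beyond the scatter) at that carbon. No measurement shown explains why the 3-chlorophenyl arrangement gives the higher number.

It remains open whether the same change gives a similar step with the fluoro or chloro of compounds 1 and 3 on the core, since the pair shown carries only the methyl. Going by these compounds, it is also open how this assay responds on the sulfonyl sulfur to a phenyl without chlorine, a 3-methoxyphenyl or a pyridine, or to an amine or carboxylic acid on the phenyl ring.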